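Swapping a Ring for a Chain on the Amide Carbonyl

The compounds below may be only part of what the source reports. "The series", "measured", "known", "first", "only" and "open" are said of these compounds alone.

In an ADME assay on isolated protein for pharmacokinetics, with UDP-glucuronosyltransferase 1A9 (Homo sapiens) as the target, read by LC-MS, with a stated time of 60 min, at 37 degrees C, tested at 1 uM, in the presence of a further agent that is not named here (a lower number here means that the compound disappears faster, a higher number that the compound lasts longer), compound 1 `O=C(NCCSc1nonc1/C(=N/O)Nc1ccc(F)c(C(F)F)c1)C1CS(=O)(=O)C1` reaches only the limit of the measurement, giving > 3 h. Compound 2 `NS(=O)(=O)CC(=O)NCCSc1nonc1/C(=N/O)Nc1ccc(F)c(Br)c1` gives 0.758 h in this assay. Compound 3 `CS(=O)(=O)CC(=O)NCCSc1nonc1/C(=N/O)Nc1ccc(F)c(C(F)F)c1` has not yet been measured; it differs from compound 1 in that (a group of 5 heavy atoms (2 carbon, 2 oxygen, 1 sulfur; no ring) in place of a group of 6 heavy atoms (3 carbon, 2 oxygen, 1 sulfur; one four-membered non-aromatic ring with 1 hetero atom), on a carbonyl carbon), that is, a group of 5 heavy atoms (2 carbon, 2 oxygen, 1 sulfur; no ring) in place of a group of 6 heavy atoms (3 carbon, 2 oxygen, 1 sulfur; one four-membered non-aromatic ring with 1 hetero atom), on a carbonyl carbon. Compound 1 stands at a limit (the limit of > 3 h in this assay, at which 1 of the 2 values shown sits), so only a modest shortening is expected, an at least 1.5-fold lower number from compound 1 to compound 3 (0.17 log units; that floor lies within the scatter). Compound 3 is estimated at 2 h, likely between 0.8 h and 4.5 h.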

Compound 3, half-life: 1.59 h
Compound 3: middle estimate off by 1.3-fold (0.10 log units), on the high side; low and high end bracket the measured number.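

Putting (methylsulfonyl)methyl in place of the four-membered ring on this carbonyl carbon gives an at least 1.8-fold lower number from compound 1 to compound 3 (0.27 log units; that floor lies within the scatter). Compound 3 thus provides a readable half-life at this position in this assay, but the true size of the step remains unknown because compound 1 is only a limit: the limit of > 3 h in this assay, at which 1 of the 3 values shown sits.

On these data alone, whether a longer chain or an amine in this place would give a similar half-life stays open. Compound 2 differs from compound 3 in more than one place and offers no comparison here.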